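A smaller two-ring group on the shared core

A few compounds are considered here, and "the series" means these few. Any claim that something is new, unique, unknown or untested is made for them only; others in the source may bear on it.

In a physicochemical assay for lipophilicity, using the shake flask method, measured as octanol-water partition, at pH 7.4 (a lower number here means a more polar compound, a higher number a more lipophilic compound), compound 1 `CC(=O)N[C@@H]1CCC[C@H](C(=O)Nc2cc(-c3cnc(C)n3C)c(Cl)cn2)C1` gives 2.2 and compound 2 `CC(=O)N[C@@H]1CCC[C@H](C(=O)Nc2cc(-c3cnc4ccccn34)c(Cl)cn2)C1` gives 3. Compound 3 `CC(=O)N[C@@H]1CCC[C@H](C(=O)Nc2cc(-c3cnn4c3CN(C)CC4)c(Cl)cn2)C1` reads 2.1 and shares the low end of these three numbers with compound 1, the two lying within the scatter of each other. Compound 4 `CC(=O)N[C@@H]1CCC[C@H](C(=O)Nc2cc(-c3cnn4c3NCCC4)c(Cl)cn2)C1` is still unmeasured. Its change is a group of 9 heavy atoms (6 carbon, 3 nitrogen; one five-membered aromatic ring with 2 hetero atoms, one six-membered non-aromatic ring with 2 hetero atoms) in place of a group of 10 heavy atoms (7 carbon, 3 nitrogen; one five-membered aromatic ring with 2 hetero atoms, one six-membered non-aromatic ring with 2 hetero atoms), on an aromatic carbon, opposite the ring nitrogen and ortho to a chloro group.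

Among the compounds with values here, no measured pair tests this exact exchange, but three steps offer guidance. The two that involve the six-membered aromatic ring are modest: a number 0.80 log units higher from compound 1 to compound 2 (beyond the scatter) and a number 0.90 log units lower from compound 2 to compound 3 (beyond the scatter). Compound 4 keeps both ring types of compound 3, so the closer guide is a number 0.10 log units lower from compound 1 to compound 3 (within the scatter). In this assay the expected result is therefore no step beyond the scatter, and the estimated change is a number 0.10 log units higher from compound 3 to compound 4 (within the scatter). For compound 4 the expected value is 2.2, within an estimated range of 1.8 to 2.6.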

Compound 4, distribution coefficient: 2.4
Compound 4: the middle estimate sits 0.20 log units below what was measured; the range from low to high includes it.
By their numbers in this assay, from the lowest: compounds 3, 1 and 4 (each within the scatter of the next); then compound 2.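

In this assay, the change at this position brings in a group with 1 hydrogen-bond donor in place of one with 0, at 9 rather than 10 heavy atoms, and the two-ring type is kept: a number 0.30 log units higher from compound 3 to compound 4 (within the scatter). Compound 4 stays apart from the compound whose group has a six-membered aromatic ring, a number 0.60 log units lower from compound 2 to compound 4 (beyond the scatter), and does not separate from the compound with the single-ring group, a number 0.20 log units higher from compound 1 to compound 4 (within the scatter), so among these four compounds only compound 2 stands apart from the rest. No measurement available here accounts for these numbers.

The compounds shown do not separate the effect of the hydrogen-bond donor from that of the change in heavy atoms. They also leave open how a carboxylic acid or a primary amine on this aromatic carbon would read in this assay.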